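The source may hold more compounds than are shown below. What is called first, only, known or untested is meant among the compounds shown, and "the series" means these compounds.

Compound 1 `C=C1CCC2[C@](C)(CO)[C@H](O)CC[C@@]2(C)[C@@H]1CCn1ccnc1`: > 50000 nM, a limit
Compound 2 `C=C1CCC2[C@](C)(CO)[C@H](O)CC[C@@]2(C)[C@@H]1CCn1cncn1`: > 100000 nM, a limit
Compound 3 `C=C1CCC2[C@](C)(CO)[C@H](O)CC[C@@]2(C)[C@@H]1CCOc1ccc([N+](=O)[O-])cc1`: 3380 nM

For the measured compounds named here, in a functional assay on RAW264.7 cells (Mus musculus) for inhibition, read by Griess assay, with stated times of 3 h and 24 h (on this read-out lower numbers stand for stronger inhibition and higher numbers for weaker inhibition), compound 3 gives 3380 nM, the only true number among the three. Going by the values given here, the other two values are limits, so the one measured step, a step that the two limits leave unreadable from compound 1 to compound 2, has no readable size. That step also concerns a different change, so it offers no size to carry over.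

The next compound is compound 4 `C=C1CCC2[C@](C)(CO)[C@H](O)CC[C@@]2(C)[C@@H]1CCOC(=O)c1cccnc1`. The change is (pyridin-3-yl)carbonyl in place of 4-nitrophenyl on an oxygen on a saturated carbon, in words (pyridin-3-yl)carbonyl in place of 4-nitrophenyl on an oxygen on a saturated carbon. Among the compounds with values here, no measured step covers this replacement, and the expectation rests on thin grounds. Compound 1, with its 1H-imidazol-1-yl ring, stands at the limit > 50000 nM. Compound 2, with its 1H-1,2,4-triazol-1-yl ring, stands at the limit > 100000 nM. Both hint that a nitrogen-containing ring may not be favoured, so a shift toward higher numbers in this assay is expected, namely a 3.6-fold higher number from compound 3 to compound 4 (0.55 log units; beyond the scatter). For compound 4 the estimate is 12000 nM, with an expected range of 3500 nM to 50000 nM.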

Compound 4, half-maximal inhibitory concentration: > 50000 nM
Compound 4 was reported as a limit; the forecaster's own chance of this, stated with the estimate: 30%; at least 4.1-fold (0.61 log units) between middle value and limit.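

In this assay, (pyridin-3-yl)carbonyl in place of 4-nitrophenyl on the oxygen gives an at least 14-fold higher number from compound 3 to compound 4 (1.17 log units; beyond the scatter), so keeping an oxygen on the chain does not by itself preserve the measurable inhibition seen with 4-nitrophenyl. For the compounds shown here, compound 4 is recorded only as a limit, which leaves compound 3 as the only compound here with a true number: the limit of > 50000 nM in this assay, at which 2 of the 4 values shown sit. The steps joining compound 4 to compound 1 and compound 2 cannot be read, since each has a limit at both ends.

The compounds shown leave open whether the loss follows the carbonyl, the ring nitrogen or both, as the replacement differs from 4-nitrophenyl in both. A plain benzoyl group on the same oxygen, or a pyridin-3-yl ring set directly on it, would separate the two.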